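The compounds below may be only part of what the source reports. "The series", "measured", "known", "first", "only" and "open" are said of these compounds alone.

Compound 1 `COc1cc(/C=C/C(=O)c2cccc(NC(=O)c3ccc(Cl)cc3Cl)c2)ccc1O`: 51%
Compound 2 `COc1cc(/C=C/C(=O)c2cccc(NC(=O)c3ccccc3)c2)ccc1O`: 48%

In a functional assay on HUVEC cells (Homo sapiens) for inhibition, tested at 5 ug/mL (on this read-out lower numbers stand for a weaker effect and higher numbers for a stronger effect at the one concentration tested), compound 2 gives 48%, and compound 1 gives 51%, the two standing within the scatter of each other. Compound 3 `COc1cc(/C=C/C(=O)c2cccc(NC(C)=O)c2)ccc1O` differs from compound 2 by methyl in place of phenyl on a carbonyl carbon. Within the data shown here, the one measured step, a number 3 percentage points lower from compound 1 to compound 2 (within the scatter), put phenyl in place of 2,4-dichlorophenyl on a carbonyl carbon and left the number within the scatter; no measured step exchanges phenyl for methyl. The step of a number 3 percentage points lower from compound 2 to compound 3 (within the scatter) is therefore expected to stay small, in no clear direction. Compound 3 is estimated at 45%, between 28% and 62%.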

Compound 3, a percentage reported as inhibition, at one concentration (the size of the read-out at that concentration, not a potency): 15%
Estimate against measurement, compound 3: 30 percentage points above; measured number outside the range, below it.
By their numbers in this assay, from the lowest: compound 3; then compounds 2 and 1 (each within the scatter of the next).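

In this assay the group on the carbonyl carbon now proves to matter: methyl in place of phenyl gives a number 33 percentage points lower from compound 2 to compound 3 (beyond the scatter) and methyl in place of 2,4-dichlorophenyl gives a number 36 percentage points lower from compound 1 to compound 3 (beyond the scatter) in the same way. The earlier pair showed only that exchanging 2,4-dichlorophenyl for phenyl left the number within the scatter, whereas removing the ring altogether costs much of the effect. No available evidence explains this drop. As far as these compounds go, whether a ring is needed, or any group beyond methyl would serve, remains open. A longer chain such as butyl, or a cyclohexyl group, on the same carbonyl carbon would separate these two readings.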